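Swapping Chloro for Nitro on the Aryl Ring

A few compounds are considered here, and "the series" means these few. Any claim that something is new, unique, unknown or untested is made for them only; others in the source may bear on it.

Compound 3 `Nc1scc(-c2ccc(Cl)cc2)c1C(=O)c1ccc(Cl)cc1` gives 50% in a functional assay on CHO cells for agonist activity at adenosine receptor A1 (Homo sapiens), read by fluorescence and ERK phosphorylation, with stated times of 30 min and 1.5 h, tested at 10 uM (a higher number here means a stronger effect of the compound at the concentration tested, a lower number a weaker effect), the lowest of the three numbers shown, though only one gap is beyond the scatter. Compound 1 `Nc1scc(-c2ccc(Cl)cc2)c1C(=O)c1ccccc1` gives 51% there, a gap within the scatter, while compound 2 `Nc1scc(-c2ccccc2)c1C(=O)c1ccc(Cl)cc1` gives 64%, a gap beyond it. Compound 4 `Nc1scc(-c2ccc([N+](=O)[O-])cc2)c1C(=O)c1ccc(Cl)cc1` differs from compound 3 as follows: nitro in place of chloro on an aromatic carbon. Within the data shown here, no measured step swaps chloro for nitro. The nearest comparison is a number 14 percentage points lower from compound 2 to compound 3 (beyond the scatter), which placed a chloro on the aromatic carbon that now carries the nitro; a number 1 percentage points lower from compound 1 to compound 3 (within the scatter) concerns a different ring. Since neither step tests nitro itself, the step of no change at the digits printed from compound 3 to compound 4 (within the scatter) is expected to stay near the scatter, with no clear direction. Compound 4 is therefore estimated at 50%, ranging from 30% to 70%.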

Compound 4, a percentage reported as activity, at one concentration (the size of the read-out at that concentration, not a potency): 52%
Estimate against measurement, compound 4: 2 percentage points below; the range from low to high includes it.
By their numbers in this assay, from the lowest: compounds 3, 1 and 4 (each within the scatter of the next); then compound 2.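

On the aromatic carbon para to a large group, nitro in place of chloro brings three heavy atoms for one and two hydrogen-bond acceptors for none, yet the swap gives a number 2 percentage points higher from compound 3 to compound 4 (within the scatter). Nitro in place of hydrogen gives a number 12 percentage points lower from compound 2 to compound 4 (beyond the scatter), so a second, different group at this position also reads lower than hydrogen, as chloro did. No measurement shown here explains these numbers.

Going by these compounds, whether an amine or a carboxylic acid at this position would read like chloro and nitro or like hydrogen remains open.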